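This account rests on a few compounds, and the source may have more. Where it says the series, first, only, none or still open, it means among the compounds named here.

Working notes on the series. Compound 3 `CN1CCN(c2ccc(Nc3nc(-c4cccc(NC(=O)c5ccccc5F)c4)sc3C(=O)O)cc2)CC1` gives 6300 nM in a functional assay on Ramos cells (Homo sapiens) for antiproliferative activity, read by CCK-8 assay, with a stated time of 72 h (on this read-out lower numbers stand for stronger inhibition and higher numbers for weaker inhibition), and holds the lowest of the two numbers recorded; compound 1 `CCOC(=O)c1sc(-c2cccc(NC(=O)c3ccc(F)c(Cl)c3)c2)nc1Nc1ccc(N2CCN(C)CC2)cc1` shows 29200 nM in this assay, a gap beyond the scatter, and for compound 2 `CN1CCN(c2ccc(Nc3nc(-c4cccc(NC(=O)c5ccccc5)c4)sc3C(=O)O)cc2)CC1` this assay reports "not determined" (no result reported). Compound 4 `CN1CCN(c2ccc(Nc3nc(-c4cccc(NC(=O)c5ccc(F)c(Cl)c5)c4)sc3C(=O)O)cc2)CC1` is the next compound to be measured in this assay. It differs from compound 3 in one place: 3-chloro-4-fluorophenyl in place of 2-fluorophenyl on a carbonyl carbon. For the measured compounds named here, no step between measured compounds covers this change, so its size is unknown. A modest shift towards a higher number, near the edge of the scatter, is expected from compound 3 to compound 4, that is a 1.6-fold higher number from compound 3 to compound 4 (0.20 log units; within the scatter). Compound 4 is estimated at 10000 nM, with a range from 3000 nM to 40000 nM.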

Compound 4, half-maximal inhibitory concentration: 5600 nM
Compound 4: middle estimate off by 1.8-fold (0.25 log units), on the high side; the range from low to high includes it.
By their numbers in this assay, from the lowest: compounds 4 and 3 (each within the scatter of the next); then compound 1.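

In this assay 3-chloro-4-fluorophenyl in place of 2-fluorophenyl on a carbonyl carbon gives a 1.1-fold lower number from compound 3 to compound 4 (0.05 log units; within the scatter) and so stays within the scatter, showing that this position accepts either aryl group with no measurable difference. Hydrogen in place of ethyl on an oxygen next to a carbonyl group gives a 5.2-fold lower number from compound 1 to compound 4 (0.72 log units; beyond the scatter) and gives the first direct reading of the carboxylic acid against its ethyl ester. No measurement at hand accounts for either step. The compounds shown leave open whether a cyclohexyl group on that carbonyl carbon gives a similar number, and whether a primary amide in place of the carboxylic acid holds the lower number.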